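The compounds below may be only part of what the source reports. "The series", "measured", "known", "first", "only" and "open" are said of these compounds alone.

Working notes on the series, values from a toxicity assay on HUVEC cells (Homo sapiens) for inhibition; on this read-out higher numbers stand for weaker inhibition of growth and lower numbers for stronger inhibition of growth:

- compound 1 (`Cc1nc(-c2ccccc2)c(C(=O)N2CCN(c3cccc(C)c3C)CC2)o1`) gives 0.38 ug/mL
- compound 2 (`Cc1ccc(C)c(N2CCN(C(=O)c3oc(C)nc3-c3ccccc3)CC2)c1`) gives 1.73 ug/mL
- compound 3 (`Cc1nc(-c2ccccc2F)c(C(=O)N2CCN(c3cc(Cl)cc(Cl)c3)CC2)o1`) gives 0.177 ug/mL

Compound 3 has the lowest number of the three. Compound 4 (`COc1cc(OC)cc(N2CCN(C(=O)c3oc(C)nc3-c3ccccc3F)CC2)c1`) carries 3,5-dimethoxyphenyl in place of 3,5-dichlorophenyl on an amine nitrogen in a ring. Within the data shown here, no measured step covers this exchange. The nearest evidence is a change of the group on the same nitrogen (a 4.6-fold higher number from compound 1 to compound 2 (0.66 log units; beyond the scatter)), so a modest step is expected, toward a higher number in this assay given the low position of compound 3. The expected step is (a 3.4-fold higher number from compound 3 to compound 4 (0.53 log units; beyond the scatter)). For compound 4 the estimated value is 0.6 ug/mL (expected range 0.18 ug/mL to 2 ug/mL).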

Compound 4, concentration for 50% growth inhibition: 0.118 ug/mL
Compound 4: middle estimate off by 5.1-fold (0.71 log units), on the high side; the whole stated range lies above it.
By their numbers in this assay, from the lowest: compounds 4 and 3 (each within the scatter of the next); then compound 1; then compound 2.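

In this assay, 3,5-dimethoxyphenyl in place of 3,5-dichlorophenyl on the amine nitrogen in the ring gives a 1.5-fold lower number from compound 3 to compound 4 (0.18 log units; within the scatter), so these two groups cannot be told apart on this read-out. The earlier step at this nitrogen, a 4.6-fold higher number from compound 1 to compound 2 (0.66 log units; beyond the scatter), lay beyond the scatter, so not every exchange here leaves the number unchanged. No measurement on hand explains either outcome.

Open, as far as these compounds go, is whether a phenyl bearing hydroxyl or dimethylamino groups in place of the methoxy groups would also stay within the scatter of compound 4. Equally open, from the compounds shown here alone, is whether an unsubstituted phenyl would.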